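The source may hold more compounds than are shown below. What is called first, only, known or untested is meant among the compounds shown, and "the series" means these compounds.

Three compounds in one series share a core and differ in the groups on the aryl urea. Compound 1 `CNc1nccc(N2CC[C@H](NC(=O)Nc3ccc(CN(C)C)c(C(F)(F)F)c3)C2)n1` carries a (dimethylamino)methyl group and a trifluoromethyl group; compound 2 `CNc1nccc(N2CC[C@H](NC(=O)Nc3ccc(C)c(Cl)c3)C2)n1` carries a methyl and a chlorine; compound 3 `O=C(Nc1ccc(Cl)c(C(F)(F)F)c1)N[C@H]1CCN(c2ccnc(NC3CC3)n2)C1` carries a chlorine and a trifluoromethyl group together with a cyclopropyl on the amine of the core. In an ADME assay on a cell-free system (plasma, Mus musculus) for protein binding, compound 1 gives 87.8%, compound 2 gives 98.6%, and compound 3 gives 99.9%. Of the three, compound 1 has the largest unbound fraction, and both gaps, to compound 2 and to compound 3, lie beyond the scatter.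

Compound 4 `CCN1CCN(Cc2ccc(NC(=O)N[C@H]3CCN(c4ccnc(NC)n4)C3)cc2C(F)(F)F)CC1` keeps the trifluoromethyl group and differs from compound 1 in one place: 4-ethylpiperazin-1-yl in place of dimethylamino on a saturated chain carbon bound to an aromatic carbon. For the measured compounds named here, no pair of measured compounds shows this change, so its effect can only be guessed. A step from compound 1 to compound 4 of a 1.5-fold lower unbound fraction from compound 1 to compound 4 (0.18 log units; within the scatter) towards more binding is expected, close to the edge of the scatter. Compound 4 is therefore estimated at 92%, within a range from 82% to 97%.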

Compound 4, plasma protein binding: 85.4%
For compound 4 the middle estimate is 1.8-fold (0.26 log units) (unbound fraction) below the measured one, and the stated range covers the measured number.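

In this assay, putting 4-ethylpiperazin-1-yl in place of dimethylamino on a saturated chain carbon bound to an aromatic carbon gives a 1.2-fold higher unbound fraction from compound 1 to compound 4 (0.08 log units; within the scatter). For the compounds shown here, this is the first pair that differs in one place only, and it shows that this position can take a group of 8 heavy atoms with a six-membered non-aromatic ring instead of one of 3 heavy atoms, with no change beyond the scatter in this assay. Nothing available explains why the two groups read alike. From the compounds shown here alone, whether this holds for other groups at the same place, such as a morpholin-4-yl ring or a carboxylic acid, remains open. Also open, going by these compounds, is whether the same swap would read alike with a cyclopropyl on the amine of the core.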